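Working notes: from compound 3 to compound 4

A few compounds are considered here, and "the series" means these few. Any claim that something is new, unique, unknown or untested is made for them only; others in the source may bear on it.

Values so far in an ADME assay on NHDF cells (Homo sapiens) for cytotoxicity, read by MTT assay, with a stated time of 72 h; on this read-out higher numbers stand for weaker inhibition and lower numbers for stronger inhibition
- compound 1 `COc1cccc(/C=C2\CCC/C(=C\c3ccccc3Cl)C2=O)c1OC` gives 44200 nM
- compound 2 `COc1ccc(/C=C2\CCC/C(=C\c3cccc(OC)c3OC)C2=O)cc1` gives 43500 nM
- compound 3 `COc1ccc(/C=C2\CCC/C(=C\c3cccc(Br)c3)C2=O)cc1OC` gives 12400 nM

Compound 3 has the lowest number of the three in this assay, and its gaps to both other compounds lie beyond the scatter. The next compound is compound 4 `COc1ccc(/C=C2\CCC/C(=C\c3cccc(Cl)c3Cl)C2=O)cc1OC`, not yet measured. It carries 2,3-dichlorophenyl in place of 3-bromophenyl on a double-bonded chain carbon bound to a double-bonded ring carbon.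

Within the data shown here, only one measured step bears on this exchange. It falls at the same place but involves other groups: a 1.0-fold lower number from compound 1 to compound 2 (0.01 log units; within the scatter). That step lies within the scatter. It offers a single precedent for a swap at this place that leaves the number within the scatter, and it gives no direction. Among the measured compounds shown here, no measured pair contains the exchange itself, so the evidence is thin and the range has to stay wide. The upper end approaches the number of compound 2 at 43500 nM.

No step beyond the scatter is expected, and the estimated step is a 1.2-fold higher number from compound 3 to compound 4 (0.08 log units; within the scatter). For compound 4 the expected value is 15000 nM, with an estimated range from 6000 nM to 38000 nM.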

Compound 4, half-maximal inhibitory concentration: 18500 nM
Compound 4: middle estimate off by 1.2-fold (0.09 log units), on the low side; the measured number falls inside the stated range.
By their numbers in this assay, from the lowest: compounds 3 and 4 (each within the scatter of the next); then compounds 2 and 1 (each within the scatter of the next).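

In this assay, among these compounds, the exchange on a double-bonded chain carbon bound to a double-bonded ring carbon gives a 1.5-fold higher number from compound 3 to compound 4 (0.17 log units; within the scatter), the first measured pair that contains this exchange: 3-bromophenyl leaves, 2,3-dichlorophenyl enters, and the heavy-atom count goes from 7 to 8 with the two chlorine atoms replacing the single bromine. Together with a 1.0-fold lower number from compound 1 to compound 2 (0.01 log units; within the scatter), this makes two different swaps at this place that both stay within the scatter, so among the substituted phenyl groups shown, the place has not yet produced a step beyond it. Nothing measured on these compounds offers an explanation for the size of this step.

Both steps involve only substituted phenyl groups, so the compounds shown leave open whether a phenyl group carrying an amine or a carboxylic acid at this place would also stay within the scatter in this assay. They also leave open whether the exchange of 3-bromophenyl for 2,3-dichlorophenyl would give a step of similar size with a different group on the other double-bonded chain carbon.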